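A few compounds are considered here, and "the series" means these few. Any claim that something is new, unique, unknown or untested is made for them only; others in the source may bear on it.

Compound 1 `COc1ccc(/C=C/C(=O)/C=C/c2ccc(OCc3cn(CCCCOc4cc(=O)oc5ccccc45)nn3)c(OC)c2)cc1OC` gives 59%
Compound 2 `COc1cc(/C=C/C(=O)/C=C/c2cccs2)ccc1OCc1cn(CCOc2cc(=O)oc3ccccc23)nn1` gives 76%

In a functional assay on THP-1 cells (Homo sapiens) for inhibition, read by sulforhodamine B assay, with a stated time of 48 h, tested at 50 uM (a lower number here means less inhibition of growth, a higher number more inhibition of growth at the concentration tested), compound 1 gives 59% as the lower of the two numbers, a gap to compound 2 that lies beyond the scatter. Compound 3 `COc1cc(/C=C/C(=O)/C=C/c2cccs2)ccc1OCc1cn(CCCCOc2cc(=O)oc3ccccc23)nn1` alters compound 1 in one place: thiophen-2-yl in place of 3,4-dimethoxyphenyl on a double-bonded chain carbon bound to a double-bonded chain carbon with thiophen-2-yl in place of 3,4-dimethoxyphenyl on a double-bonded chain carbon bound to a double-bonded chain carbon. Among the compounds with values here, compound 2, which also carries thiophen-2-yl, reaches 76% in this assay, so a modest rise is expected, although no measured pair shows this change alone. The expected move is a number 9 percentage points higher from compound 1 to compound 3 (within the scatter) in this assay as a rough estimate. The estimate for compound 3 is 68% with 52% to 84% as its expected range.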

Compound 3, percent growth inhibition at one concentration: 44%
The estimate for compound 3 lay 24 percentage points above the measured number; the whole stated range lies above it.
By their numbers in this assay, from the lowest: compound 3; then compound 1; then compound 2.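

At this place, on a double-bonded chain carbon bound to a double-bonded chain carbon, putting thiophen-2-yl in place of 3,4-dimethoxyphenyl gives a number 15 percentage points lower from compound 1 to compound 3 (beyond the scatter) in this assay. Thiophen-2-yl therefore does not bring a high number by itself: compound 2 carries it too and gives 76%, while compound 3 gives 44%. No measurement at hand explains this drop. Still open, from the compounds shown here alone, is how an aminophenyl or a carboxylic acid at this place would read in this assay. Also open, going by these compounds, is whether the same swap gives a similar step on the chain of compound 2.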